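Swapping sec-butyl for oxolan-2-yl on a shared core

This account rests on a few compounds, and the source may have more. Where it says the series, first, only, none or still open, it means among the compounds named here.

Compound 1, `COc1cc(Cc2nc3c(N)ncnc3n2CCCO)cc(OC)c1OC`: 92700000 nM
Compound 2, `CC[C@H](C)Cn1c(Cc2cc(OC)c(OC)c(OC)c2)nc2c(N)nc(F)nc21`: 66700000 nM

Both compounds were tested in a functional assay on MCF7 cells (Homo sapiens) for cytotoxicity (on this read-out higher numbers stand for an effect only at larger amounts of compound and lower numbers for an effect already at smaller amounts), and both sit at very large concentrations, meaning that neither shows an effect until a great deal of compound is present. Compound 2 stands alongside compound 1 on this read-out; the gap between them is within the scatter of the assay, so the two cannot be told apart.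

The next compound, compound 3, `COc1cc(Cc2nc3c(N)nc(F)nc3n2CC2CCCO2)cc(OC)c1OC`, is not yet measured. It keeps the core of compound 2 and changes one place: oxolan-2-yl in place of sec-butyl on a saturated chain carbon bound to an aromatic nitrogen. Among the measured compounds shown here, no measured pair shows what this kind of change does here, so there is no precedent to lean on.

Given how close compound 1 and compound 2 already lie, the expectation for compound 3 is a step from compound 2 that stays within the scatter, with no direction to call: a 1.0-fold higher number from compound 2 to compound 3 (0.02 log units; within the scatter). Compound 3 is thus estimated at 70000000 nM, with a range from 20000000 nM to 200000000 nM.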

Compound 3, half-maximal effective concentration: 147000000 nM
For compound 3 the middle estimate is 2.1-fold (0.32 log units) below the measured one; measured number inside the range.
By their numbers in this assay, from the lowest: compounds 2, 1 and 3 (each within the scatter of the next, the first and the last beyond it).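

Among the compounds shown here, on the saturated chain carbon bound to an aromatic nitrogen, oxolan-2-yl in place of sec-butyl gives the first single-place comparison in this assay (a 2.2-fold higher number from compound 2 to compound 3 (0.34 log units; beyond the scatter)). This position is therefore not wholly indifferent to the group it carries: the exchange brings in a five-membered ring with one oxygen and one hydrogen-bond acceptor, and compound 3 needs somewhat more compound for the same effect. Nothing measured here accounts for the step, and the part played by the oxygen or by the ring remains unassigned.

A cyclopentyl group at this place, which keeps a ring but has no oxygen, would help separate the two, while a 3-methoxypropyl chain would keep an oxygen without a ring. Going by these compounds, it also remains open what an amine or a carboxylic acid would do on this chain, and whether any group here could bring the effect down to much smaller amounts of compound.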